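Compound 3 and a ring one carbon larger

The source may hold more compounds than are shown below. What is called first, only, known or untested is meant among the compounds shown, and "the series" means these compounds.

Measured in an ADME assay on liver for metabolic stability, with Liver microsome (Homo sapiens) as the target, using microsomes; on this read-out higher numbers stand for fast clearance and lower numbers for slow clearance:
compound 1 `CC(=O)Nc1cc(Nc2cc(NC3CC3)n3ncc(C#N)c3n2)ccc1NCCCO` gives 21 mL.min-1.g-1
compound 2 `CC(=O)Nc1cc(Nc2cc(NC3CC3)n3ncc(C#N)c3n2)ccc1N1CC[C@H](N(C)C)C1` gives 9 mL.min-1.g-1
compound 3 `CC(=O)Nc1cc(Nc2cc(NC3CC3)n3ncc(C#N)c3n2)ccc1N1CC[C@@H](N)C1` gives < 3 mL.min-1.g-1 as a limit

Compound 3 gives < 3 mL.min-1.g-1 as a limit of the assay and not as a number. It therefore has no exact place in the series, although both of the other compounds read higher. The next compound is compound 4 `CC(=O)Nc1cc(Nc2cc(NC3CC3)n3ncc(C#N)c3n2)ccc1N1CCC[C@@H](N)C1` with the change 3-aminopiperidin-1-yl in place of 3-aminopyrrolidin-1-yl on an aromatic carbon on the shared core, in words 3-aminopiperidin-1-yl in place of 3-aminopyrrolidin-1-yl on an aromatic carbon.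

Among the measured compounds shown here, no measured step changes ring size alone. The three steps at this same place are a 2.3-fold lower number from compound 1 to compound 2 (0.37 log units; beyond the scatter) and an at least 7.0-fold lower number from compound 1 to compound 3 (0.84 log units; beyond the scatter) and an at least 3.0-fold lower number from compound 2 to compound 3 (0.47 log units; beyond the scatter) and they show that this assay responds to this group. The closest guide is an at least 3.0-fold lower number from compound 2 to compound 3 (0.47 log units; beyond the scatter) with the five-membered ring kept. Its size marks a rough upper bound for a change that leaves the primary amino group in place. A small rise is the likelier direction, since compound 3 has only a limit and a fall could not be read as a number.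

The expected change is an at least 1.6-fold higher number from compound 3 to compound 4 (0.22 log units; that floor lies within the scatter) and this remains an estimate. For compound 4 the expected value is 5 mL.min-1.g-1 with a range from 3 mL.min-1.g-1 to 12 mL.min-1.g-1 as the estimate.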

Compound 4, intrinsic clearance in microsomes: < 3 mL.min-1.g-1
Compound 4 gave a limit, no number; the forecaster's own chance of this, stated with the estimate: 30%; middle value at least 1.6-fold (0.22 log units) from the limit.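

In this assay compound 4 gives < 3 mL.min-1.g-1, which is a limit of the assay and not a number. With 3-aminopiperidin-1-yl on the aromatic carbon ortho to the acetamido group, the series shows an at least 3.0-fold lower number from compound 2 to compound 4 (0.47 log units; beyond the scatter) and an at least 7.0-fold lower number from compound 1 to compound 4 (0.84 log units; beyond the scatter), so the low reading at this position is not confined to the five-membered ring of compound 3. The step between compound 3 and compound 4 cannot be read, because both compounds stand at the same limit: the limit of < 3 mL.min-1.g-1 in this assay, at which 2 of the 4 values shown sit.

On these data alone, whether the six-membered and five-membered rings differ at all in this assay stays open while both compounds give only a limit. Also open, as far as these compounds go, is how much of the low reading goes with the primary amino group and how much with the ring, a question that a 3-(dimethylamino)piperidin-1-yl or a 3-hydroxypiperidin-1-yl group at the same position would address, as would the opposite stereocentre of the 3-aminopiperidin-1-yl group.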